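A Methyl Added to the Ring of Compound 1

The source may report more compounds than this note shows. Statements on the series, on what has been measured and on what is new or still open speak of the compounds shown alone.

Within the data shown here, in a functional assay on A-431 cells (Homo sapiens) for inhibition, with a stated time of 72 h (on this read-out lower numbers stand for stronger inhibition and higher numbers for weaker inhibition), compound 1 (`CCOCc1cc(CN2CCCCC2)c(O)c2ncccc12`) gives 23400 nM, the higher of the two numbers so far, and compound 2 (`CCCOCc1cc(CN2CCCCC2)c(O)c2ncccc12`) gives 6760 nM. Compound 3 (`CCOCc1cc(CN2CCC(C)CC2)c(O)c2ncccc12`) differs from compound 1 by methyl in place of hydrogen on a saturated ring carbon. Among the measured compounds shown here, the only measured step, a 3.5-fold lower number from compound 1 to compound 2 (0.54 log units; beyond the scatter), also adds a methyl, but on a saturated chain carbon, so it is a loose guide. A similar or smaller drop is therefore expected in this assay. For compound 3 the estimate is 11000 nM, within 4000 nM to 28000 nM. This would be an expected 2.1-fold lower number from compound 1 to compound 3 (0.33 log units; beyond the scatter).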

Compound 3, half-maximal inhibitory concentration: 11000 nM
Estimate against measurement, compound 3: no gap at the digits printed; low and high end bracket the measured number.
By their numbers in this assay, from the lowest: compounds 2 and 3 (each within the scatter of the next); then compound 1.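

In this assay the change from piperidin-1-yl to 4-methylpiperidin-1-yl gives a 2.1-fold lower number from compound 1 to compound 3 (0.33 log units; beyond the scatter) and so shows that the read-out also responds at this saturated ring carbon, three ring bonds from the ring nitrogen, a place where compounds 1 and 2 do not differ. The step is modest, yet it lies beyond the scatter. No measurement here bears on what lies behind it. From the compounds shown here alone, it remains open whether an ethyl, a phenyl or a hydroxyl at this ring carbon would move the number further. Going by these compounds, it also remains open whether this methyl and the longer chain of compound 2 would add up in one molecule.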